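Lengthening the amide chain of a bicyclic diacid amide

The source may report more compounds than this note shows. Statements on the series, on what has been measured and on what is new or still open speak of the compounds shown alone.

The series rests on a shared core, seen in compound 1 `CCCCNC(=O)C1C(C(=O)O)[C@@H]2CC[C@H]1O2`, compound 2 `CCOC(=O)c1cn[nH]c1NC(=O)C1C(C(=O)O)[C@@H]2CC[C@H]1O2` and compound 3 `O=C(O)c1ccc(NC(=O)C2C(C(=O)O)[C@@H]3CC[C@H]2O3)cc1Cl`. In an ADME assay on A-431 cells (Homo sapiens) for cytotoxicity, read by MTT assay, with a stated time of 72 h (a lower number here means a stronger inhibitor of growth, a higher number a weaker inhibitor of growth), compound 1 gives 10000 nM. In this assay compound 2 gives 10000 nM and compound 3 gives 10000 nM, so compound 1 stands level with both of them, within the scatter. Compound 4 `CCCCCCCCNC(=O)C1C(C(=O)O)[C@@H]2CC[C@H]1O2` is not yet measured. It differs from compound 1 by butyl in place of hydrogen on a saturated chain carbon, four bonds along the chain from an amide-type nitrogen. For the measured compounds named here, nothing among the measured compounds shows the effect of such a change, since all three share one value, and the step expected in this assay is none beyond the scatter. Compound 4 is therefore expected to give 10000 nM (range 4000 nM to 20000 nM), a step of no change at the digits printed from compound 1 to compound 4 (within the scatter).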

Compound 4, concentration for 50% growth inhibition: 10000 nM
Beside the measured number, compound 4's estimate shows no gap at the digits printed, and the stated range covers the measured number.
By their numbers in this assay, from the lowest: compounds 1, 2, 3 and 4 (each within the scatter of the next).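

In this assay, for the compounds shown here, butyl in place of hydrogen on a saturated chain carbon, four bonds along the chain from an amide-type nitrogen, gives no change at the digits printed from compound 1 to compound 4 (within the scatter) and is the first step that can be read in one place. At this position, then, the longer chain of compound 4 leaves the reading level with that of compound 1. No supporting evidence bears on this result.

The compounds shown leave open whether a chain ending in an amine, or a chain longer than that of compound 4, would shift the value.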